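This account rests on a few compounds, and the source may have more. Where it says the series, first, only, none or still open, it means among the compounds named here.

Measured so far:
Compound 1 `COc1cc(-c2nc(N)n(CC(=O)Nc3ccc(/C(C)=N\O)cc3)n2)cc(OC)c1OC`: 3.93%
Compound 2 `c1ccc(-c2nc3sc(-c4ccccc4)cn3n2)cc1`: 11%

In a functional assay on K562 cells (Homo sapiens) for inhibition, read by sulforhodamine B assay, with a stated time of 48 h, tested at 10 uM (a higher number here means more inhibition of growth at the concentration tested, a lower number less inhibition of growth), compound 1 gives 3.93% and compound 2 gives 11%. Among the compounds with values here, of the two numbers, the one for compound 2 is the higher, but its gap to compound 1 lies within the usual scatter, so the two cannot be told apart. Compound 3 `Clc1ccc(-c2cn3nc(-c4ccccc4)nc3s2)cc1` has not been measured. It differs from compound 2 by chloro in place of hydrogen on an aromatic carbon. Within the data shown here, no measured pair shows this change, so only a small step is expected, in either direction or none beyond the scatter, and a number 3 percentage points higher from compound 2 to compound 3 (within the scatter) is the estimated step. Compound 3 is expected to give 14%, between 0% and 35%.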

Compound 3, percent growth inhibition at one concentration: 24%
Estimate against measurement, compound 3: 10 percentage points below, and the stated range covers the measured number.
By their numbers in this assay, from the lowest: compounds 1 and 2 (each within the scatter of the next); then compound 3.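

Within the data shown here, the change from phenyl to 4-chlorophenyl gives a number 13 percentage points higher from compound 2 to compound 3 (beyond the scatter) in this assay and is the first single-place change in this set. It shows that this position on the six-membered aromatic ring can respond to one added chlorine atom, although the step is modest and rests on one pair. Nothing available here explains the rise. Going by these compounds, whether an amine, a methoxy group or a carboxylic acid at this position would raise the number, lower it or leave it unchanged remains open. So does whether chloro would give a similar step elsewhere on the shared core.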